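Ester aryl substituents on the shared core: next step

The source may report more compounds than this note shows. Statements on the series, on what has been measured and on what is new or still open speak of the compounds shown alone.

Compound 1 `CC1=CC[C@H]2[C@H](CC[C@]2(C)O)C(C)(C)[C@@H]1CC[C@H]1[C@]2(C)CC[C@H](OC(=O)c3ccc(Cl)cc3)C(C)(C)O[C@H]2CC[C@@]1(C)O` gives 10300 nM in a functional assay on MDA-MB-231 cells (Homo sapiens) for antiproliferative activity, read by MTT assay, with a stated time of 72 h; on this read-out higher numbers stand for weaker inhibition and lower numbers for stronger inhibition.
Compound 2 `CC1=CC[C@H]2[C@H](CC[C@]2(C)O)C(C)(C)[C@@H]1CC[C@H]1[C@]2(C)CC[C@H](OC(=O)c3ccc([N+](=O)[O-])cc3)C(C)(C)O[C@H]2CC[C@@]1(C)O` gives 8900 nM in this assay.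
Compound 3 `COc1ccc(C(=O)O[C@H]2CC[C@]3(C)[C@H](CC[C@@](C)(O)[C@H]3CC[C@@H]3C(C)=CC[C@H]4[C@H](CC[C@]4(C)O)C3(C)C)OC2(C)C)cc1` gives 30600 nM in this assay.

Compound 3 holds the highest number of the three in this assay: a 3.0-fold higher number from compound 1 to compound 3 (0.47 log units; beyond the scatter) and a 3.4-fold higher number from compound 2 to compound 3 (0.54 log units; beyond the scatter). Compound 4 `CC1=CC[C@H]2[C@H](CC[C@]2(C)O)C(C)(C)[C@@H]1CC[C@H]1[C@]2(C)CC[C@H](OC(=O)c3ccc(C(F)(F)F)c(F)c3)C(C)(C)O[C@H]2CC[C@@]1(C)O` differs from compound 3 by 3-fluoro-4-(trifluoromethyl)phenyl in place of 4-methoxyphenyl on a carbonyl carbon. The two measured steps that bear on this both remove the methoxy and both gave modestly lower numbers; compound 4 removes the same methoxy, so a lower number of similar size is expected, a 3.1-fold lower number from compound 3 to compound 4 (0.49 log units; beyond the scatter). The entering group matches neither chloro nor nitro, so the range is kept wide. Compound 4 is expected to give 10000 nM in this assay, between 4000 nM and 30000 nM.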

Compound 4, half-maximal inhibitory concentration: 22200 nM
For compound 4 the middle estimate is 2.2-fold (0.35 log units) below the measured one; measured number inside the range.
By their numbers in this assay, from the lowest: compounds 2 and 1 (each within the scatter of the next); then compounds 4 and 3 (each within the scatter of the next).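

In this assay the exchange of 4-methoxyphenyl for 3-fluoro-4-(trifluoromethyl)phenyl on this carbonyl carbon reads a 1.4-fold lower number from compound 3 to compound 4 (0.14 log units; within the scatter) and leaves the pair level, so losing the methoxy does not by itself bring the number down at this position. The same entering group stands apart from the other two esters, with a 2.5-fold higher number from compound 2 to compound 4 (0.40 log units; beyond the scatter) and a 2.2-fold higher number from compound 1 to compound 4 (0.33 log units; beyond the scatter) at this same place. No measured data explain this split.

Still open, on these data alone, is how an amine or a carboxylic acid on the aromatic ring, or a longer chain in its place, would read, and whether any of these gives a number clearly below those of compound 2 and compound 1.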